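Methylsulfanyl for Hydroxymethyl on a Dopamine Transporter Series

This account rests on a few compounds, and the source may have more. Where it says the series, first, only, none or still open, it means among the compounds named here.

Measured so far:
compound 1, `CNC[C@]1(O)Cc2ccccc2[C@@H]1Oc1ccccc1CO`: > 10000 nM
compound 2, `CNC[C@]1(O)Cc2ccccc2[C@@H]1Oc1ccc(O)cc1C`: 5000 nM
compound 3, `CNCC1(O)Cc2ccccc2C1Cc1ccccc1C`: > 10000 nM

Of the compounds shown here, three have been tested in an in vitro assay on HEK293 cells for inhibition of sodium-dependent dopamine transporter (Homo sapiens); on this read-out lower numbers stand for stronger inhibition and higher numbers for weaker inhibition. For compound 1 the read-out is a limit of this assay, not a number, > 10000 nM. Compound 3 likewise reaches only a limit, > 10000 nM. Compound 2 gives a number, 5000 nM. Compound 1 therefore stands at the weak end of what is shown, at the limit of > 10000 nM in this assay, at which 2 of the 3 values shown sit.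

Compound 4, `CNC[C@]1(O)Cc2ccccc2[C@@H]1Oc1ccccc1SC`, has not been measured. It differs from compound 1 in one place: methylsulfanyl in place of hydroxymethyl on an aromatic carbon. Among the measured compounds shown here, no measured pair in this assay shows this change, so no step can be read from the data, and the expectation rests on compound 1 alone. With compound 1 only at a limit, the step from compound 1 to compound 4 is expected to be small in this assay, if any, and may stay within the scatter; the expected step is an at least 1.2-fold lower number from compound 1 to compound 4 (0.09 log units; that floor lies within the scatter). Compound 4 is expected to give about 8000 nM in this assay, within 2000 nM to 30000 nM.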

Compound 4, half-maximal inhibitory concentration: > 10000 nM
Compound 4 was reported as a limit; the forecaster's own chance of this, stated with the estimate: 50%; middle value at least 1.2-fold (0.09 log units) away from the limit.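

In this assay compound 4 gives > 10000 nM, which is a limit of the assay. Among the compounds shown here, compound 1 also stands at a limit, so no step from compound 1 to compound 4 can be read: the limit of > 10000 nM in this assay, at which 3 of the 4 values shown sit. The compounds shown leave open whether methylsulfanyl in place of hydroxymethyl changes inhibition at all.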